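A Larger Aromatic Group in Place of 4-Methylphenyl

The compounds below may be only part of what the source reports. "The series", "measured", "known", "first", "only" and "open" are said of these compounds alone.

Compound 1 `Cc1ccc(-c2cn(/N=C/c3cc4ccccc4nc3Cl)c(N)n2)cc1`, compound 2 `Nc1nc(-c2ccc(Br)cc2)cn1/N=C/c1cc2ccccc2nc1Cl` and compound 3 `Cc1ccc(-c2cn(/N=C/c3cc4cc(C)ccc4nc3Cl)c(N)n2)cc1` share one core and were tested in an ADME assay on HUVEC cells (Homo sapiens) for cytotoxicity, read by MTT assay, with a stated time of 48 h; a higher number here means a weaker inhibitor, a lower number a stronger inhibitor. For compound 1 the result is only a limit of the assay, > 50000 nM, as recorded in the limit of > 50000 nM in this assay, at which 1 of the 3 values shown sits. Compound 2 gives 11900 nM. Compound 3 gives 18000 nM, the higher of the two numbers, though its gap to compound 2 lies within the scatter. Going from compound 1 to compound 2 gave an at least 4.2-fold lower number from compound 1 to compound 2 (0.62 log units; beyond the scatter), and going from compound 1 to compound 3 gave an at least 2.7-fold lower number from compound 1 to compound 3 (0.44 log units; beyond the scatter).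

Compound 4 `Cc1ccc2nc(Cl)c(/C=N/n3cc(-c4cccc5ccccc45)nc3N)cc2c1` differs from compound 3 by naphthalen-1-yl in place of 4-methylphenyl on an aromatic carbon. For the measured compounds named here, of the two measured steps, only the one from compound 1 to compound 2 altered the aromatic group attached at this same place, with bromo in place of methyl, and it lowered the number. Going by the values given here, no measured step replaces one aromatic group by a larger one, so the expectation is cautious: a modest lowering is expected, a 1.8-fold lower number from compound 3 to compound 4 (0.26 log units; within the scatter). Compound 4 is therefore estimated at 10000 nM, with a range from 4000 nM to 30000 nM.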

Compound 4, half-maximal inhibitory concentration: 9580 nM
Compound 4: the middle estimate sits 1.0-fold (0.02 log units) above what was measured; the measured number falls inside the stated range.
By their numbers in this assay, from the lowest: compounds 4, 2 and 3 (each within the scatter of the next). At a limit, above all of these: compound 1.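

The earlier compounds shown here changed only what the aromatic group at this place carries, bromo in place of methyl, whereas here the whole group on the five-membered aromatic ring with 2 nitrogen is exchanged, and one six-membered aromatic ring of carbon gives way to two. In this assay this larger exchange gave a 1.9-fold lower number from compound 3 to compound 4 (0.27 log units; within the scatter) and so the number does not tell 4-methylphenyl and naphthalen-1-yl apart. Nothing measured here says why these two groups read alike.

Going by these compounds, whether this place also accepts a group that is not an all-carbon aromatic ring, such as an amine, a carboxylic acid or a longer alkyl chain, stays open. Also open, on these data alone, is whether naphthalen-1-yl would give the same picture on the core of compound 1, without the added methyl.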